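Swapping bromo for methyl on a shared amide-linked core

A few compounds are considered here, and "the series" means these few. Any claim that something is new, unique, unknown or untested is made for them only; others in the source may bear on it.

Of the compounds shown here, three built on one shared core have been tested in a functional assay on SMMC-7721 cells (Homo sapiens) for cytotoxicity, read by MTT assay, with a stated time of 72 h; on this read-out higher numbers stand for weaker inhibition and lower numbers for stronger inhibition. Compound 1, `O=C(CSC(=S)N[C@H]1CCOC1=O)Nc1ccc(Br)cc1`, gives 28300 nM in this assay. Compound 2, `Cc1cccc(NC(=O)CSC(=S)N[C@H]2CCOC2=O)c1C`, gives 42200 nM, and compound 3, `O=C(CSC(=S)N[C@H]1CCOC1=O)Nc1ccccc1Cl`, gives 49900 nM. Compound 1 shows the lowest of the three numbers, yet its gaps to compound 2 and compound 3 both lie within the scatter of this assay, so the three cannot be told apart with confidence. Within the data shown here, the only single-point step among them, a 1.8-fold higher number from compound 1 to compound 3 (0.25 log units; within the scatter), is likewise within the scatter.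

Compound 4, `Cc1ccc(NC(=O)CSC(=S)N[C@H]2CCOC2=O)cc1`, differs from compound 1 by a single change: methyl in place of bromo on an aromatic carbon. Among the measured compounds shown here, no measured step involves a methyl entering for a bromo, so nothing directly bears on this change. For the measured compounds named here, the one step that is known, from compound 1 to compound 3, concerns a different swap and stays within the scatter, and the three measured values all sit close together. On that basis compound 4 is expected to sit near compound 1, with a 1.2-fold higher number from compound 1 to compound 4 (0.09 log units; within the scatter) amounting to no step beyond the scatter. The estimate for compound 4 in this assay is 35000 nM, with a range from 15000 nM to 85000 nM.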

Compound 4, half-maximal inhibitory concentration: 32700 nM
Estimate against measurement, compound 4: 1.1-fold (0.03 log units) above; measured number inside the range.
By their numbers in this assay, from the lowest: compounds 1, 4, 2 and 3 (each within the scatter of the next).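

Among these compounds, this gives the first direct reading of the aromatic carbon para to a large group in this assay: replacing bromo with methyl, one bromine atom exchanged for one carbon atom, gives a step that stays within the scatter (a 1.2-fold higher number from compound 1 to compound 4 (0.06 log units; within the scatter)). At this position, then, the two groups cannot be told apart on this read-out, and 4-bromophenyl and 4-methylphenyl serve equally well as far as these numbers can show. The second new comparison (a 1.5-fold lower number from compound 3 to compound 4 (0.18 log units; within the scatter)) is also within the scatter, so 2-chlorophenyl and 4-methylphenyl cannot be separated either, and no measurement shown here offers any explanation for these results.

Bromo and methyl are the only two groups compared directly at this position, so the compounds shown leave open whether a quite different group there, such as an amine, a carboxylic acid or a longer chain like butyl, would produce a step beyond the scatter. They also leave open whether methyl and bromo would remain indistinguishable on a different cell line or read-out.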